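Replacing bromo with 2,6-dimethylphenyl: solubility of compound 4

This account rests on a few compounds, and the source may have more. Where it says the series, first, only, none or still open, it means among the compounds named here.

Measured so far in a physicochemical assay for solubility, read by HPLC, using the shake flask method, measured as kinetic solubility, with a stated time of 2 h, at pH 7.4; on this read-out lower numbers stand for lower solubility and higher numbers for higher solubility:
compound 1 `Cc1cc(NCc2ccccn2)n2ncc(Br)c2n1` gives 89300 nM;
compound 2 `Cc1cc(NCc2cnccn2)n2nc(C)c(-c3ccccc3)c2n1` gives 7100 nM;
compound 3 `Cc1cc(Nc2ccccn2)n2nc(C)c(-c3ccccc3)c2n1`, whose value is a limit of the assay, gives < 5000 nM.

Compound 1 stands highest of the two numbers recorded in this assay. Its nearest neighbour is compound 2, whose number lies lower by a gap beyond the usual scatter; compound 2 differs from compound 1 in more than one place, so only the two values themselves can be compared. Among the measured compounds shown here, the only step measured in one place is an at least 1.4-fold lower number from compound 2 to compound 3 (0.15 log units; that floor lies within the scatter), which concerns the group on the ring nitrogen and not the position changed here, so it bears on compound 4 only indirectly. For compound 3 the outcome is a limit, (the limit of < 5000 nM in this assay, at which 1 of the 3 values shown sits).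

Compound 4 `Cc1cc(NCc2ccccn2)n2ncc(-c3c(C)cccc3C)c2n1` differs from compound 1 in one place: 2,6-dimethylphenyl in place of bromo on an aromatic carbon.

For the measured compounds named here, no measured step covers this exact change. Going by the values given here, compound 2, which carries an aromatic carbon ring at this position among its differences, gives 7100 nM, a number that sits under the one recorded for compound 1. On that ground compound 4 is expected to give a lower number, with the step estimated as a 9.9-fold lower number from compound 1 to compound 4 (1.00 log units; beyond the scatter). Compound 4 is therefore estimated at 9000 nM, within 3000 nM to 30000 nM.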

Compound 4, solubility: < 5000 nM
Compound 4 ended at the assay's limit (the forecaster's own chance of this, stated with the estimate: 25%); middle value at least 1.8-fold (0.25 log units) from the limit.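

In this assay, among the compounds shown here, this is the first change at this position that can be read in one place, and the result is an at least 17-fold lower number from compound 1 to compound 4 (1.25 log units; beyond the scatter). For compound 4 the value < 5000 nM is a limit of the assay, so the step gives a floor for the size of the change and not its full size. The earlier compounds carried an aromatic carbon ring at this position only together with other differences, whereas here bromo leaves and 2,6-dimethylphenyl enters on the same aromatic carbon with the rest of compound 1 unchanged, so the lower number belongs to this one change, and the readings at the low end of the scale now crowd against the same limit: the limit of < 5000 nM in this assay, at which 2 of the 4 values shown sit.

On these data alone, it stays open whether the lower number goes with the six-membered aromatic ring itself or with its two methyl groups, and how far under the limit compound 4 really lies. As far as these compounds go, it also stays open whether an amine or a carboxylic acid on this aromatic carbon, in place of bromo, would hold the number near that of compound 1.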